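Tetrazole in place of propyl on the benzamide ring

A few compounds are considered here, and "the series" means these few. Any claim that something is new, unique, unknown or untested is made for them only; others in the source may bear on it.

The series is followed in a functional assay on the whole organism (stomach) with Rattus norvegicus as the target; on this read-out higher numbers stand for an effect only at larger amounts of compound and lower numbers for an effect already at smaller amounts. Compound 1 `O=C(Nc1ccc(-c2nn[nH]n2)cc1)c1cccc(-c2nn[nH]n2)c1` gives 0.6 mg/kg in this assay. Compound 2 `CCCc1ccc(C(=O)Nc2cc(C(=O)O)cc(C(=O)O)c2)cc1` gives 94.2 mg/kg in this assay, and compound 3 `N#Cc1cccc(C(=O)Nc2cc(C(=O)O)cc(C(=O)O)c2)c1` gives 140 mg/kg in this assay. Among the three numbers compound 2 stands second highest; its nearest neighbour is compound 3, within the scatter, while compound 1 lies far lower, beyond the scatter. Going by the values given here, no pair among the measured compounds differs in one place only, so no single step is available as a yardstick.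

Compound 4 `O=C(O)c1cc(NC(=O)c2ccc(-c3nn[nH]n3)cc2)cc(C(=O)O)c1` is unmeasured. It differs from compound 2 in one place: 2H-tetrazol-5-yl in place of propyl on an aromatic carbon.

Among the compounds with values here, the only compound carrying the entering group, compound 1, shows the low number of this set, but it differs from compound 4 in more than one place, so the comparison is loose. A step from compound 2 toward a lower number, beyond the scatter, is expected, with the size as in a 4.7-fold lower number from compound 2 to compound 4 (0.67 log units; beyond the scatter). For compound 4 the estimated value in this assay is 20 mg/kg, expected to fall between 3 mg/kg and 80 mg/kg.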

Compound 4, dose for 50% inhibition: 8.2 mg/kg
Estimate against measurement, compound 4: 2.4-fold (0.39 log units) above, and the stated range covers the measured number.
By their numbers in this assay, from the lowest: compound 1; then compound 4; then compounds 2 and 3 (each within the scatter of the next).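

Going by these compounds alone, at this position, on an aromatic carbon para to a large group, 2H-tetrazol-5-yl in place of propyl gives an 11-fold lower number from compound 2 to compound 4 (1.06 log units; beyond the scatter) in this assay, the only single-place step so far. The position is therefore not indifferent to its substituent: with the rest of the structure held constant, this one change moves the number beyond the scatter, and the lower number comes with a five-membered aromatic ring in place of a plain chain. No measurement on hand bears on the origin of this step, and the feature of the entering group responsible stays unassigned.

As far as these compounds go, it remains open whether the step reflects the gain of 2H-tetrazol-5-yl or the loss of propyl, which an amine or a longer chain on the same carbon would help to separate. From the compounds shown here alone, whether a step of this size also holds on the core of compound 1 is likewise open.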